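Small step expected on the carbonyl carbon

The source may report more compounds than this note shows. Statements on the series, on what has been measured and on what is new or still open speak of the compounds shown alone.

Measured in a functional assay on HT-29 cells (Homo sapiens) for inhibition, read by CellTiter-Glo, with a stated time of 72 h; a higher number here means that more compound is tolerated, a lower number that less compound is tolerated:
- compound 1 `CC1=C(CC(=O)N(C)CCN(C)C)c2cc(F)ccc2/C1=C\c1nc2ccccc2s1`: 2020 nM
- compound 2 `CC1=C(CC(=O)N2CCN(CCCN(C)C)CC2)c2cc(F)ccc2/C1=C\c1ccc([S+](C)[O-])cc1`: 23800 nM
- compound 3 `CC1=C(CC(=O)NCCN2CCCC2)c2cc(F)ccc2/C1=C\c1nc2ccccc2s1`: 1210 nM

In this assay compound 3 cannot be told apart from compound 1, and both stand well under compound 2. Compound 4 `CC1=C(CC(=O)N2CCN(CCCN(C)C)CC2)c2cc(F)ccc2/C1=C\c1nc2ccccc2s1` has 4-(3-(dimethylamino)propyl)piperazin-1-yl in place of (2-(pyrrolidin-1-yl)ethyl)amino on a carbonyl carbon. Going by the values given here, only one measured step changes this place, a 1.7-fold lower number from compound 1 to compound 3 (0.22 log units; within the scatter), and it stayed within the scatter. It involved a smaller replacement, so it is only a limited guide. Compound 2 already carries the entering group, but the rest of its structure differs from compound 4, so its value cannot simply be carried over. It does give some reason to lean upward. The expected change is a 1.7-fold higher number from compound 3 to compound 4 (0.22 log units; within the scatter), which is not expected to exceed the scatter. Compound 4 is estimated at 2000 nM, with an expected range from 600 nM to 7000 nM.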

Compound 4, half-maximal cytotoxic concentration: 1620 nM
Beside the measured number, compound 4's estimate is 1.2-fold (0.09 log units) above it; measured number inside the range.
By their numbers in this assay, from the lowest: compounds 3, 4 and 1 (each within the scatter of the next); then compound 2.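

In this assay the carbonyl carbon takes a far larger replacement than the earlier step had tested without a change that can be told from the scatter: 4-(3-(dimethylamino)propyl)piperazin-1-yl, which has no hydrogen-bond donor, gives a 1.3-fold higher number from compound 3 to compound 4 (0.13 log units; within the scatter) and a 1.2-fold lower number from compound 1 to compound 4 (0.10 log units; within the scatter). With the group on the carbonyl carbon held the same, the replacement on the double-bonded chain carbon gives a 15-fold lower number from compound 2 to compound 4 (1.17 log units; beyond the scatter), which places the wide gap to compound 2 at that site and not on the carbonyl carbon. No evidence is available to explain any of these steps.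

Going by these compounds, whether the flat response on the carbonyl carbon extends to a morpholine amide, which has only one nitrogen, or to a carboxylic acid remains open. So does whether the gap at the double-bonded chain carbon holds with other groups on the carbonyl carbon.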